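The compounds below may be only part of what the source reports. "The series", "measured", "known", "first", "only" and "open" are said of these compounds alone.

Among the measured compounds shown here, the series so far holds two measured compounds, both read in a functional assay on HL-60 cells (Homo sapiens) for cytotoxicity, read by WST assay, with a stated time of 48 h; a lower number here means that less compound is needed, a higher number that more compound is needed for the effect. There compound 1 `COc1ccccc1C[C@H]1C(=O)OC[C@@H]1Cc1ccccc1` gives 79000 nM and compound 2 `COCOc1ccccc1C[C@H]1C(=O)OC[C@@H]1Cc1ccccc1` gives 76000 nM. The two numbers lie within the scatter of each other, so compound 2 stands level with compound 1. The next structure is compound 3 `CCCCOc1ccccc1C[C@H]1C(=O)OC[C@@H]1Cc1ccccc1`, reached by the change propyl in place of methoxy on a saturated chain carbon bound to an oxygen on an aromatic ring, or, cut one bond further out, methoxymethoxy to butoxy. For the measured compounds named here, only one measured step bears on this place, a 1.0-fold lower number from compound 1 to compound 2 (0.02 log units; within the scatter), which put methoxy in place of hydrogen and stayed within the scatter. Going by the values given here, that step involves a different pair of groups, and no measured compound carries butoxy, so the evidence is thin. No step beyond the scatter is expected in this assay, though the range is kept wide. The estimated step is a 1.3-fold lower number from compound 2 to compound 3 (0.10 log units; within the scatter). For compound 3 the expected value is 60000 nM, with an estimated range of 25000 nM to 120000 nM.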

Compound 3, half-maximal effective concentration: 20000 nM
The estimate for compound 3 lay 3.0-fold (0.48 log units) above the measured number; measured number outside the range, below it.
By their numbers in this assay, from the lowest: compound 3; then compounds 2 and 1 (each within the scatter of the next).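

In this assay the place on a saturated chain carbon bound to an oxygen on an aromatic ring now shows that it can move the number: propyl in place of methoxy gives a 3.8-fold lower number from compound 2 to compound 3 (0.58 log units; beyond the scatter) here, whereas the earlier change gave only a 1.0-fold lower number from compound 1 to compound 2 (0.02 log units; within the scatter) and stayed within the scatter. Measured against the shorter end of the series, propyl in place of hydrogen gives a 4.0-fold lower number from compound 1 to compound 3 (0.60 log units; beyond the scatter) as a step of similar size, so butoxy stands apart from both methoxy and methoxymethoxy, which remain level with each other. No measurement on hand bears on the cause of this step.

Methoxymethoxy and butoxy differ in both chain make-up and heavy-atom count, so the compounds shown do not separate the loss of the chain oxygen from the change in chain length, and ethoxy or propoxy would be needed to tell these apart. Also open, as far as these compounds go, is whether a longer chain such as hexyloxy continues the fall in the number, and how a chain ending in an amine or a carboxylic acid would read at this place.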